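Removing a tert-butyl group: cytotoxicity of a nitroimidazooxazole

The compounds below may be only part of what the source reports. "The series", "measured", "known", "first", "only" and "open" are said of these compounds alone.

Measured so far:
compound 1, `CC1Cn2c(nc([N+](=O)[O-])c2C#Cc2cccc(N)c2)O1`: 18100 nM
compound 2, `CC1Cn2c(nc([N+](=O)[O-])c2C#Cc2ccc(C(C)(C)C)cc2)O1`: 6620 nM

Of the compounds shown here, two on the shared core have been tested in an ADME assay on CHO cells (Cricetulus griseus) for cytotoxicity, read by MTT assay, with a stated time of 24 h; on this read-out lower numbers stand for higher toxicity in this test and higher numbers for lower toxicity in this test. Compound 1 gives 18100 nM, while compound 2 gives 6620 nM. Compound 2 therefore stands at the lowest of the two numbers; its nearest neighbour is compound 1, whose value is higher by a gap that lies beyond the usual scatter of the test.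

Compound 3, `CC1Cn2c(nc([N+](=O)[O-])c2C#Cc2ccccc2)O1`, remains to be measured in this assay. It differs from compound 2 in one place: hydrogen in place of tert-butyl on an aromatic carbon.

Among the measured compounds shown here, no step between two measured compounds matches this change, so the expectation rests only on compound 2 itself. Because compound 2 gives 6620 nM and compound 1 gives 18100 nM, compound 3 is expected to land between or near these two numbers. The expected step is a 1.8-fold higher number from compound 2 to compound 3 (0.26 log units; within the scatter), a moderate rise. Compound 3 is estimated at 12000 nM, within a range from 5000 nM to 30000 nM.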

Compound 3, half-maximal cytotoxic concentration: 3540 nM
Beside the measured number, compound 3's estimate is 3.4-fold (0.53 log units) above it, outside the stated range (below it).
By their numbers in this assay, from the lowest: compounds 3 and 2 (each within the scatter of the next); then compound 1.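

Taking tert-butyl off the aromatic carbon does not move the result clearly in this assay: the printed step, a 1.9-fold lower number from compound 2 to compound 3 (0.27 log units; within the scatter), shows that this large group can be exchanged for hydrogen on this carbon without a change that can be told from the usual variation between repeats. Among the compounds shown here, exchanging amino for hydrogen gives a different picture, with a 5.1-fold lower number from compound 1 to compound 3 (0.71 log units; beyond the scatter), so of the two single changes leading to compound 3, only this one gives a step that can be read. Nothing measured here accounts for either step.

The compounds shown leave open whether a smaller alkyl group such as methyl, or a carboxylic acid, at the place held by tert-butyl would also stay close to compound 3. They also leave open whether a methoxy group or a hydroxyl group in place of amino would give a number nearer to compound 1 or to compound 3.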